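A sulfanyl ether swap on a weak growth inhibitor

A few compounds are considered here, and "the series" means these few. Any claim that something is new, unique, unknown or untested is made for them only; others in the source may bear on it.

Among the measured compounds shown here, compound 1 `Nc1cc(N)c2nc(-c3ccccc3)c(Oc3ccc(Cl)c(Cl)c3)nc2c1` is the only compound with a full number in a functional assay on COLO 205 cells (Homo sapiens) for inhibition, read by sulforhodamine B assay, with a stated time of 48 h; a lower number here means a stronger inhibitor of growth, a higher number a weaker inhibitor of growth: there compound 1 gives 67600 nM. Compound 2 `COc1ccc(CNc2nc3cc(N)cc(N)c3nc2-c2ccccc2)cc1OC` is the other compound in the set; in this assay compound 2 gives only < 100000 nM, which is a limit of the assay and not a number, so one of the two values shown is a limit (the limit of < 100000 nM in this assay, at which 1 of the 2 values shown sits). For the measured compounds named here, no step between two measured compounds is available to guide expectations. Compound 3 `Nc1cc(N)c2nc(-c3ccccc3)c(Sc3ccc(F)cc3)nc2c1` has not yet been measured. It differs from compound 1 by (4-fluorophenyl)sulfanyl in place of 3,4-dichlorophenoxy on an aromatic carbon. Going by the values given here, with no measured step on the shared core, the expected change is a 1.1-fold lower number from compound 1 to compound 3 (0.05 log units; within the scatter), none beyond the usual scatter. Compound 3 is therefore estimated at 60000 nM in this assay, within a range from 20000 nM to 150000 nM.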

Compound 3, concentration for total growth inhibition: 47900 nM
Compound 3: the middle estimate sits 1.3-fold (0.10 log units) above what was measured; the range from low to high includes it.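

In this assay the exchange at this aromatic carbon gives a 1.4-fold lower number from compound 1 to compound 3 (0.15 log units; within the scatter), so the step leaves the number where it was within the usual scatter. Among the compounds shown here, it is the only measured step on the shared core, and it shows that (4-fluorophenyl)sulfanyl can stand in place of 3,4-dichlorophenoxy without a change beyond the scatter, although the linking atom and the ring substituents change together and this step cannot separate them. For the compounds shown here, compound 2 remains a limit of the assay and not a number, so it adds no step: the limit of < 100000 nM in this assay, at which 1 of the 3 values shown sits.

The compounds shown leave open whether anything at this carbon moves the number beyond the scatter, for example a carboxylic acid or a longer alkyl chain. They also leave open what sulfur alone does when the 3,4-dichlorophenyl ring is kept.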